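Fluoro to methoxy on the aryl ring of the alkyne series

The source may hold more compounds than are shown below. What is called first, only, known or untested is meant among the compounds shown, and "the series" means these compounds.

Among the measured compounds shown here, compound 2 `FCc1nc(C#Cc2cccc(F)c2)cs1` is one of two compounds measured so far in an assay on membranes from brain for displacement of a labelled ligand from metabotropic glutamate receptor 5 (Rattus norvegicus) (a higher number here means a weaker inhibitor, a lower number a stronger inhibitor), where compound 2 gives 0.48 nM. Compound 1 `N#Cc1cccc(C#Cc2csc(CF)n2)c1` in this assay gives 0.06 nM, so compound 2 holds the higher of the two numbers, and the step from compound 1 to compound 2 is an 8.0-fold higher number from compound 1 to compound 2 (0.90 log units; beyond the scatter).

The next compound, compound 3 `COc1cccc(C#Cc2csc(CF)n2)c1`, differs from compound 2 in one place: methoxy in place of fluoro on an aromatic carbon. For the measured compounds named here, no measured pair involves a methoxy group, so the only step available for comparison is the cyano-to-fluoro step, an 8.0-fold higher number from compound 1 to compound 2 (0.90 log units; beyond the scatter), which concerns a different pair of groups at the same place and does not bear directly on the present change. Going by the values given here, the series therefore gives no direct guide; with one substituent exchange on the same aryl carbon, and a step of modest size seen for the only prior exchange there, no change beyond the scatter is expected in this assay.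

The step from compound 2 to compound 3 is estimated as a 1.2-fold lower number from compound 2 to compound 3 (0.08 log units; within the scatter). For compound 3 the expected value in this assay is 0.4 nM, with a range from 0.1 nM to 1.5 nM.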

Compound 3, half-maximal inhibitory concentration: 0.52 nM
Compound 3: middle estimate off by 1.3-fold (0.11 log units), on the low side; the measured number falls inside the stated range.
By their numbers in this assay, from the lowest: compound 1; then compounds 2 and 3 (each within the scatter of the next).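

In this assay, the exchange on this aromatic carbon, meta to a group of 9 heavy atoms, gives a 1.1-fold higher number from compound 2 to compound 3 (0.03 log units; within the scatter), so fluoro and methoxy cannot be told apart here, even though methoxy brings one more heavy atom and a hydrogen-bond acceptor that fluoro lacks. The earlier compounds shown here showed only that cyano and fluoro differ at this place; the step of an 8.7-fold higher number from compound 1 to compound 3 (0.94 log units; beyond the scatter) now shows a second replacement of cyano that also ends beyond the scatter, leaving compound 1 alone at the low end of the three numbers, with the two other groups read alike. Nothing available explains why cyano stands apart from these two groups or why fluoro and methoxy match.

Among the compounds shown here, with only three groups compared on this carbon, it remains open whether the low number of compound 1 is particular to cyano or would be shared by other groups, such as an amide, an amine or a carboxylic acid. On these data alone, it is also open whether a longer chain such as ethoxy would still read like methoxy in this assay, or would move the number beyond the scatter.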